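From compound 3 to compound 4: one side group exchanged

A few compounds are considered here, and "the series" means these few. Any claim that something is new, unique, unknown or untested is made for them only; others in the source may bear on it.

compound 1 `CC(C)=CCC[C@]1(C)/C=C/[C@@H](OC(=O)C=C(C)C)[C@](C)(O)/C=C/C(=O)/C(C(=O)O)=C\C1` gives > 10000 nM (a limit, not a number)
compound 2 `CC(C)=CCC[C@]1(C)/C=C/[C@@H](OC(=O)C=C(C)C)[C@](C)(O)/C=C/C(=O)/C(CN2CCN(C)CC2)=C\C1` gives 840 nM
compound 3 `CSC(=S)OC/C1=C/C[C@](C)(CCC=C(C)C)/C=C/[C@@H](OC(=O)C=C(C)C)[C@](C)(O)/C=C/C1=O` gives 180 nM

All three entries come from a functional assay on HL-60 cells (Homo sapiens) for antiproliferative activity, read by MTT assay, with a stated time of 48 h (a lower number here means a stronger inhibitor, a higher number a weaker inhibitor), and share one core. Compound 3 stands lowest of the two true numbers, and compound 2 lies nearest to it. Compound 4 `CO/N=C/C1=C/C[C@](C)(CCC=C(C)C)/C=C/[C@@H](OC(=O)C=C(C)C)[C@](C)(O)/C=C/C1=O` differs from compound 3 in one side group: a group of 4 heavy atoms (2 carbon, 1 nitrogen, 1 oxygen; no ring) in place of a group of 6 heavy atoms (3 carbon, 1 oxygen, 2 sulfur; no ring), on a double-bonded ring carbon, on a double-bonded ring carbon of the shared core. The large at least 55-fold lower number from compound 1 to compound 3 (1.74 log units; beyond the scatter) starts from a limit and gives only a loose guide. The closer guide is compound 2, with a 4.7-fold lower number from compound 2 to compound 3 (0.67 log units; beyond the scatter), so a modest step towards a higher number in this assay is expected rather than a large one. The expected change is a 2.5-fold higher number from compound 3 to compound 4 (0.40 log units; beyond the scatter). For compound 4 the estimated value is 450 nM, with an expected range from 100 nM to 2500 nM.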

Compound 4, half-maximal inhibitory concentration: 4760 nM
For compound 4 the middle estimate is 11-fold (1.02 log units) below the measured one; the measured number lies above the stated range.
By their numbers in this assay, from the lowest: compound 3; then compound 2; then compound 4. At a limit, above all of these: compound 1.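

In this assay, among these compounds, the side group on this double-bonded ring carbon can shift the number much further than the earlier compounds indicated, and two neutral, ring-free groups can differ widely, with a 26-fold higher number from compound 3 to compound 4 (1.42 log units; beyond the scatter). The group bearing the six-membered ring also gives the lower number, with a 5.7-fold higher number from compound 2 to compound 4 (0.75 log units; beyond the scatter). Against the carboxy compound the result is only a bound, an at least 2.1-fold lower number from compound 1 to compound 4 (0.32 log units; beyond the scatter), and that entry is a limit, not a number: the limit of > 10000 nM in this assay, at which 1 of the 4 values shown sits.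

The compounds shown leave open whether the methoxy group on the imine or the imine itself accounts for the higher number. A hydroxy group or a longer chain on that oxygen, or a simple primary amine on this carbon, would help to separate them.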